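From 4-fluorophenyl to 3-ethynylphenyl on a shared core

The compounds below may be only part of what the source reports. "The series", "measured", "known", "first", "only" and "open" are said of these compounds alone.

compound 1 `COc1cccc(C(=O)NCCNC(=O)[C@H](CC(=O)NC(C)(C)C)NS(=O)(=O)c2ccc(C)cc2)c1` gives 115 mL.min-1.g-1
compound 2 `Cc1ccc(S(=O)(=O)N[C@@H](CC(=O)NC(C)(C)C)C(=O)NCCNC(=O)c2ccccc2F)cc1` gives 124 mL.min-1.g-1
compound 3 `Cc1ccc(S(=O)(=O)N[C@@H](CC(=O)NC(C)(C)C)C(=O)NCCNC(=O)c2ccc(F)cc2)cc1` gives 81 mL.min-1.g-1

Compound 3 stands close to both of the others in an ADME assay on microsomes from liver (Rattus norvegicus) for pharmacokinetics (a lower number here means slower removal, a higher number faster removal of the compound), and the numbers show a 1.4-fold lower number from compound 1 to compound 3 (0.15 log units; within the scatter) as well as a 1.5-fold lower number from compound 2 to compound 3 (0.18 log units; within the scatter) in this small set. Compound 4 `C#Cc1cccc(C(=O)NCCNC(=O)[C@H](CC(=O)NC(C)(C)C)NS(=O)(=O)c2ccc(C)cc2)c1` has 3-ethynylphenyl in place of 4-fluorophenyl on a carbonyl carbon while the rest of the structure stays the same. Within the data shown here, no measured compound carries this group, so the data give no direct reading of it. The nearest guidance comes from the three measured swaps at this same place. These include a 1.1-fold higher number from compound 1 to compound 2 (0.03 log units; within the scatter) and, like the two steps above, it stays small. No change beyond the scatter is therefore expected, and the estimate is a 1.2-fold higher number from compound 3 to compound 4 (0.09 log units; within the scatter) in this series. Compound 4 is estimated at 100 mL.min-1.g-1 with an expected range from 55 mL.min-1.g-1 to 180 mL.min-1.g-1 in this measurement.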

Compound 4, intrinsic clearance in microsomes: 61 mL.min-1.g-1
Estimate against measurement, compound 4: 1.6-fold (0.21 log units) above, and the stated range covers the measured number.
By their numbers in this assay, from the lowest: compounds 4, 3, 1 and 2 (each within the scatter of the next, the first and the last beyond it).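

The 3-ethynylphenyl group fits this position in this assay without a clear break from the 4-fluorophenyl group, with a 1.3-fold lower number from compound 3 to compound 4 (0.12 log units; within the scatter). Among these compounds, it also gives the first step at this position that passes the scatter, though only modestly, with a 2.0-fold lower number from compound 2 to compound 4 (0.31 log units; beyond the scatter), while replacing methoxy with ethynyl on the aromatic carbon gives a 1.9-fold lower number from compound 1 to compound 4 (0.28 log units; within the scatter). So the aryl groups on this carbonyl now span a small but real spread, set by the two ends of the series, and nothing in the data explains why the numbers differ.

From the compounds shown here alone, all four compounds carry a substituted phenyl on this carbonyl, so how a nitrile, an amine or a carboxylic acid on that ring would move the number stays open. Going by these compounds, whether a cyclohexyl group could take the place of the phenyl is also open.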